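Removing the Methyl from Compound 3: What to Expect

The source may hold more compounds than are shown below. What is called first, only, known or untested is meant among the compounds shown, and "the series" means these compounds.

Of the compounds shown here, three have been measured in a functional assay on A-431 cells (Homo sapiens) for cytotoxicity, read by MTT assay, with a stated time of 72 h, tested at 30 uM; on this read-out higher numbers stand for more inhibition of growth at the one concentration tested and lower numbers for less inhibition of growth. Compound 1 `N/C(=N\NC(=S)N1CCOCC1)c1ccccn1` gives 78.8% in this assay. Compound 2 `Cc1cccc(/C(N)=N/NC(=S)N2CCSCC2)n1` gives 64.5%. Compound 3 `Cc1ccnc(/C(N)=N/NC(=S)N2CCSCC2)c1` gives 75.3%. Among these three numbers compound 3 stands second highest: its nearest neighbour is compound 1, whose number is higher by an amount within the scatter, and its furthest is compound 2, whose number lies lower by an amount beyond the scatter.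

Compound 4 `N/C(=N\NC(=S)N1CCSCC1)c1ccccn1` is not yet measured. It differs from compound 3 in one place: hydrogen in place of methyl on an aromatic carbon, on an aromatic carbon of a six-membered aromatic ring with 1 nitrogen, meta to a large group and opposite the ring nitrogen.

Within the data shown here, no measured pair shows this exact change, so the step from compound 3 to compound 4 in this assay is a matter of expectation alone. Because compound 1, which also carries hydrogen at this carbon, gives 78.8%, a step of no more than the scatter in either direction is expected for a number 0.7 percentage points higher from compound 3 to compound 4 (within the scatter). Compound 4 is therefore expected to give about 76% in this assay, within a range from 62% to 88%.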

Compound 4, percent growth inhibition at one concentration: 81.3%
The estimate for compound 4 lay 5.3 percentage points below the measured number; low and high end bracket the measured number.
By their numbers in this assay, from the lowest: compound 2; then compounds 3, 1 and 4 (each within the scatter of the next).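

In this assay, hydrogen in place of methyl on the aromatic carbon meta to a large group and opposite the ring nitrogen gives a number 6 percentage points higher from compound 3 to compound 4 (within the scatter) and so cannot be told apart from the scatter at this position. The same exchange gives a number 16.8 percentage points higher from compound 2 to compound 4 (beyond the scatter) when it starts from compound 2, whose methyl stands on a different ring carbon, so the two methyl steps differ in whether they exceed the scatter. Thiomorpholin-4-yl in place of morpholin-4-yl on the thiocarbonyl carbon gives a number 2.5 percentage points higher from compound 1 to compound 4 (within the scatter) and likewise stays inside the scatter.

Nothing available explains why one methyl step exceeds the scatter and the other does not. On these data alone, whether an amine, a methoxy group or a longer chain on this carbon would hold the number near that of compound 4 remains open.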